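The source may hold more compounds than are shown below. What is called first, only, known or untested is meant among the compounds shown, and "the series" means these compounds.

Compound 3 `CC(=O)NCC#Cc1ccc2c(c1)C=C([N+](=O)[O-])C(C(F)(F)F)O2` gives 7670 nM in a functional assay on 1321N1 cells for antagonist activity at P2Y purinoceptor 6 (Homo sapiens), read by fluorescence and calcium flux (on this read-out lower numbers stand for stronger inhibition and higher numbers for weaker inhibition), the highest number among the three compounds measured there. Compound 2 `CC(C)(C)C#Cc1ccc2c(c1)C=C([N+](=O)[O-])C(C(F)(F)F)O2` gives 6590 nM, and the two lie within the scatter of each other, since a 1.2-fold higher number from compound 2 to compound 3 (0.07 log units; within the scatter). Compound 1 `CC(C)(C)OC(=O)NCC#Cc1ccc2c(c1)C=C([N+](=O)[O-])C(C(F)(F)F)O2` gives 1200 nM; it stands furthest from compound 3, as a 6.4-fold higher number from compound 1 to compound 3 (0.81 log units; beyond the scatter), and also differs from compound 2, as a 5.5-fold higher number from compound 1 to compound 2 (0.74 log units; beyond the scatter).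

Compound 4 `CC[Si](C#Cc1ccc2c(c1)C=C([N+](=O)[O-])C(C(F)(F)F)O2)(CC)CC` differs from compound 3 in one place: a group of 7 heavy atoms (6 carbon, 1 silicon; no ring) in place of a group of 5 heavy atoms (3 carbon, 1 nitrogen, 1 oxygen; no ring), on a triple-bonded carbon. The group entering in compound 4 resembles the tert-butyl of compound 2 in having no hydrogen-bond donor or acceptor. Among the measured compounds shown here, the step that bears on it most directly is therefore the one between compound 2 and compound 3, and that step, a 1.2-fold higher number from compound 2 to compound 3 (0.07 log units; within the scatter), was within the scatter. The step from compound 1 to compound 3 shows that a change at this position can matter, but compound 1 carries a different group. The expected step is therefore small, a 1.4-fold lower number from compound 3 to compound 4 (0.14 log units; within the scatter), with no direction beyond the scatter. Compound 4 is estimated at 5500 nM in this assay, in a range from 2000 nM to 15000 nM.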

Compound 4, half-maximal inhibitory concentration: 604 nM
For compound 4 the middle estimate is 9.1-fold (0.96 log units) above the measured one, outside the stated range (below it).
By their numbers in this assay, from the lowest: compounds 4 and 1 (each within the scatter of the next); then compounds 2 and 3 (each within the scatter of the next).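

The position on the triple-bonded carbon proves able to carry a large change without the carbamate of compound 1: the group of 7 heavy atoms stands well apart from both the acetamidomethyl group (a 13-fold lower number from compound 3 to compound 4 (1.10 log units; beyond the scatter)) and the tert-butyl group (an 11-fold lower number from compound 2 to compound 4 (1.04 log units; beyond the scatter)). Having no hydrogen-bond donor or acceptor does not account for this on its own, as tert-butyl has none either, and the step to this group from ((tert-butoxycarbonyl)amino)methyl stays within the scatter (a 2.0-fold lower number from compound 1 to compound 4 (0.30 log units; within the scatter)). No measurement at hand explains the step.

Going by these compounds, whether the silicon atom or the three ethyl chains matter more remains open, and a trimethylsilyl group or an all-carbon triethylmethyl group on the triple-bonded carbon would bear on that. On these data alone, how a free primary amine at the end of the propargyl chain would compare also remains unknown.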